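The compounds below may be only part of what the source reports. "The series", "measured", "known", "first", "only" and "open" are said of these compounds alone.

Measured so far in an ADME assay on cells (Erythrocyte, Homo sapiens), read by hemolysis, with a stated time of 1 h; a higher number here means a weaker inhibitor, a lower number a stronger inhibitor:
Compound 1, `CC(=NNC(=S)Nc1ccccc1F)c1ccccn1`. Compound 1 gives > 10000 nM, a limit of the assay.
Compound 2, `CC(=NNC(=S)Nc1ccccc1[N+](=O)[O-])c1ccccn1`. Compound 2 gives > 10000 nM, also a limit.
Compound 3, `CC(=NNC(=S)Nc1ccc(F)cc1)c1ccccn1`. Compound 3 gives > 10000 nM, again a limit.

Every value shown therefore sits at the limit of > 10000 nM in this assay, at which 3 of the 3 values shown sit. The change from compound 1 to compound 2 is nitro in place of fluoro on an aromatic carbon; the step it made is a step that the two limits leave unreadable from compound 1 to compound 2. The difference between the core of compound 1 and the core of compound 3 is not broken down here. Compound 4, `CC(=NNC(=S)Nc1ccc([N+](=O)[O-])cc1)c1ccccn1`, is still to be measured in this assay; it differs from compound 3 by nitro in place of fluoro on an aromatic carbon. The place differs from the earlier case, ortho to a large group there, para to a large group here, so this is the same kind of change, not the same. Because the limit of > 10000 nM in this assay, at which 3 of the 3 values shown sit, holds all three values, the step is expected to be a step that the limit leaves unreadable from compound 3 to compound 4 and no larger. Compound 4 is expected to give 20000 nM, most likely again only a limit, between 10000 nM and 100000 nM.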

Compound 4, half-maximal inhibitory concentration: > 10000 nM
Compound 4 gave a limit, no number; the forecaster's own chance of this, stated with the estimate: 90%; the middle value is on the limit's open side.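

In this assay compound 3 and compound 4 both give only a limit, so no step can be read between them: the limit of > 10000 nM in this assay, at which 4 of the 4 values shown sit.

As far as these compounds go, how far any of the compounds lies from that limit, and whether nitro in place of fluoro shifts the read-out at either place, stays open.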